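The source may hold more compounds than are shown below. What is called first, only, known or untested is meant among the compounds shown, and "the series" means these compounds.

The measured compounds:

compound 1 `Fc1ccc(-c2nn3c(NC4CCCC4)cccc3c2-c2ccc3[nH]ccc3c2)cc1`: 20000 nM in an ADME assay on Vero cells (Chlorocebus sabaeus) for cytotoxicity; on this read-out lower numbers stand for higher toxicity in this test and higher numbers for lower toxicity in this test
compound 2 `Fc1ccc(-c2nn3c(NC4CCCC4)cccc3c2-c2ccnnc2)cc1`: "not determined" (no result reported) in this assay

Among the compounds with values here, compound 1 is the only compound of this set with a number in this assay, where compound 1 gives 20000 nM. Compound 2 shares the core of compound 1 and carries a pyridazin-4-yl group in place of the indolyl group, but for compound 2 the entry in this assay reads "not determined" (no result reported), so compound 2 stands on no number at all.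

Compound 3 `Fc1ccc(-c2nn3c(NC4CCCC4)cccc3c2-c2ccncc2)cc1` is not yet measured. The change from compound 2 to compound 3 is pyridin-4-yl in place of pyridazin-4-yl on an aromatic carbon, in words pyridin-4-yl in place of pyridazin-4-yl on an aromatic carbon. Within the data shown here, no pair of measured compounds shows a step in this assay that resembles this change, so neither a direction nor a size of step can be read from the data; the one number available, that of compound 1, is the only anchor. With that anchor compound 3 is expected to give about 20000 nM in this assay, with a range from 7000 nM to 60000 nM.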

Compound 3, half-maximal cytotoxic concentration: 20000 nM
The estimate for compound 3 equals the measured number at the digits printed, and the stated range covers the measured number.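

Within the data shown here, the exchange of 1H-indol-5-yl for pyridin-4-yl on an aromatic carbon of the five-membered aromatic ring gives the first step that can be read at this position in this assay and it shows no change at the digits printed from compound 1 to compound 3 (within the scatter). So, in this one pair on the shared core, the read-out does not separate the two groups, although they differ in what they bring to this position, and the earlier compounds, with only one number between them, could not show this. The step from compound 2 to compound 3 and the reverse comparison with compound 1 cannot be read, since compound 2 has no number, and the data therefore say nothing about pyridazin-4-yl. Nothing available bears on why the two groups read alike.

Open, as far as these compounds go, is whether a group of another kind at this position, such as a carboxylic acid, a primary amine or a morpholine, would move the read-out in this assay. Also open, from the compounds shown here alone, is whether the reading holds when the cyclopentylamino group or the 4-fluorophenyl group of the shared core gives way to another group.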